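A few compounds are considered here, and "the series" means these few. Any claim that something is new, unique, unknown or untested is made for them only; others in the source may bear on it.

Among the measured compounds shown here, in a functional assay on HT-29 cells (Homo sapiens) for antiproliferative activity, with a stated time of 48 h (on this read-out higher numbers stand for weaker inhibition and lower numbers for stronger inhibition), three compounds have numbers so far. Compound 1 `O=C(NCCCCl)Nc1ccc(I)cc1` gives 90000 nM. Compound 2 `CC(C)(C)c1ccc(CNC(=O)NCCCCl)cc1` gives 19000 nM. Compound 3 `CC(C)(C)c1ccc(CNC(=O)NC(=O)CCl)cc1` gives 7100 nM, the lowest of the three, so the strongest inhibition seen here. For the measured compounds named here, its nearest neighbour is compound 2, and the one change between them, (chloromethyl)carbonyl in place of 3-chloropropyl on an amide-type nitrogen, brought a 2.7-fold lower number from compound 2 to compound 3 (0.43 log units; beyond the scatter). Compound 1 differs from compound 3 in more than one place, so its far higher number is only noted, not traced to one change.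

Compound 4 `CCNC(=O)NCc1ccc(C(C)(C)C)cc1` is the next step. Relative to compound 3 the difference is ethyl in place of (chloromethyl)carbonyl on an amide-type nitrogen. Going by the values given here, only the step from compound 2 to compound 3 bears on this, and only in part: that step added the (chloromethyl)carbonyl that is now removed, but the entering ethyl also lacks the chlorine that every measured compound carries. The expected direction is therefore back towards a higher number, roughly undoing the gain seen in a 2.7-fold lower number from compound 2 to compound 3 (0.43 log units; beyond the scatter), with the uncertainty of the missing chlorine on top. The step from compound 3 to compound 4 is expected to be a 4.2-fold higher number from compound 3 to compound 4 (0.63 log units; beyond the scatter). For compound 4 the estimate is 30000 nM, within a range from 8000 nM to 120000 nM.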

Compound 4, half-maximal inhibitory concentration: > 100000 nM
Compound 4: a limit, no number (the forecaster's own chance of this, stated with the estimate: 15%); at least 3.3-fold (0.52 log units) between middle value and limit.
By their numbers in this assay, from the lowest: compound 3; then compound 2; then compound 1. At a limit, above all of these: compound 4.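

Compound 4 stands at a limit of the assay, not at a number: the limit of > 100000 nM in this assay, at which 1 of the 4 values shown sits.

On this amide-type nitrogen, ethyl in place of (chloromethyl)carbonyl brings an at least 14-fold higher number from compound 3 to compound 4 (1.14 log units; beyond the scatter), and the change of chloromethyl to hydrogen on a saturated chain carbon, two bonds along the chain from an amide-type nitrogen, brings an at least 5.2-fold higher number from compound 2 to compound 4 (0.72 log units; beyond the scatter). Among the compounds shown here, compounds 1, 2 and 3 all carry a chlorine and all give a number, so compound 4 is the first view of this position without chlorine, and both steps are larger than the modest step printed from compound 2 to compound 3 or at least beyond the scatter, which shows that the chlorine-bearing chain at this position matters far more than the choice between the two such chains.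

The compounds shown leave open whether the chlorine or the rest of the removed group accounts for the loss: an acetyl group on this nitrogen would keep the carbonyl without the chlorine, and a propyl chain would keep the length of the chain in compound 2 without it. On these data alone, whether a bromoacetyl group would serve in the same way as the (chloromethyl)carbonyl of compound 3 also stays open.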